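The compounds below may be only part of what the source reports. "The series", "measured", "known", "first", "only" and "open" are said of these compounds alone.

Measured in a functional assay on NCI-H23 cells (Homo sapiens) for antiproliferative activity, read by sulforhodamine B assay; a higher number here means a weaker inhibitor of growth, a lower number a stronger inhibitor of growth:
- compound 1 `CC(C)CCCOc1cccc(O)c1C(=O)/C=C/c1ccc(O)cc1`: 11400 nM
- compound 2 `CCCCCCOc1cccc(O)c1C(=O)/C=C/c1ccc(O)cc1`: > 30000 nM (a limit)
- compound 3 `O=C(/C=C/c1ccc(O)cc1)c1c(O)cccc1OCC1CCCCC1`: > 30000 nM (a limit)

Compound 3 has no number, only a limit, > 30000 nM. The series stands at the limit of > 30000 nM in this assay, at which 2 of the 3 values shown sit.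

Next is compound 4 `O=C(/C=C/c1ccc(O)cc1)c1c(O)cccc1OCC1CCCC1`, with cyclopentyl in place of cyclohexyl on a saturated chain carbon bound to an oxygen on an aromatic ring.

The measured steps at this place are an at least 2.6-fold higher number from compound 1 to compound 3 (0.42 log units; beyond the scatter) and a step that the two limits leave unreadable from compound 2 to compound 3. The nearby change gives an at least 2.6-fold higher number from compound 1 to compound 2 (0.42 log units; beyond the scatter). Only compound 1 gives a number, 11400 nM, so a modest step toward a lower number in this assay is expected at most. The expected step is an at least 1.2-fold lower number from compound 3 to compound 4 (0.09 log units; that floor lies within the scatter). For compound 4 the estimate is 24000 nM, with an expected range of 10000 nM to 45000 nM.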

Compound 4, concentration for 50% growth inhibition: 3160 nM
Beside the measured number, compound 4's estimate is 7.6-fold (0.88 log units) above it, and the stated range ends above it.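

Cyclopentyl in place of cyclohexyl gives an at least 9.4-fold lower number from compound 3 to compound 4 (0.97 log units; beyond the scatter) and cyclopentyl in place of pentyl gives an at least 9.4-fold lower number from compound 2 to compound 4 (0.97 log units; beyond the scatter) so a ring on this saturated chain carbon does not in itself cost growth inhibition, and ring size counts here. Against the branched chain, cyclopentyl gives a 3.6-fold lower number from compound 1 to compound 4 (0.56 log units; beyond the scatter) and this makes compound 4 the strongest of the four. The first two steps are only floors, because compound 2 and compound 3 each hold a limit and not a number: the limit of > 30000 nM in this assay, at which 2 of the 4 values shown sit.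

On these data alone, whether cyclobutyl or cyclopropyl on the same carbon goes further remains open. So does whether a cyclopentyl ring carrying an amine keeps this gain.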